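Amide nitrogen substituent and cytotoxicity in the imide series

A few compounds are considered here, and "the series" means these few. Any claim that something is new, unique, unknown or untested is made for them only; others in the source may bear on it.

Measured so far:
- Compound 1 `Cc1ccc(N2C(=O)C/C(=C\c3cccc(C(=O)Nc4ccc(Cl)cc4)c3)C2=O)cc1` gives > 100000 nM in an ADME assay on HCT-116 cells (Homo sapiens) for cytotoxicity, read by MTT assay, with a stated time of 72 h (on this read-out higher numbers stand for weaker inhibition and lower numbers for stronger inhibition), a limit of the assay.
- Compound 2 `CCOc1ccc(NC(=O)c2cccc(/C=C3\CC(=O)N(Cc4ccccc4)C3=O)c2)cc1` gives 41700 nM in this assay.
- Compound 3 `CCCCNC(=O)c1cccc(/C=C2\CC(=O)N(Cc3ccccc3)C2=O)c1` gives 95100 nM in this assay.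

Compound 3 holds the highest of the two numbers; its nearest neighbour is compound 2, with the step of a 2.3-fold higher number from compound 2 to compound 3 (0.36 log units; beyond the scatter). The remaining value, that of compound 1, is only a limit (the limit of > 100000 nM in this assay, at which 1 of the 3 values shown sits).

Compound 4 `O=C(Nc1ccc(Cl)cc1)c1cccc(/C=C2\CC(=O)N(Cc3ccccc3)C2=O)c1` differs from compound 3 in one place: 4-chlorophenyl in place of butyl on an amide-type nitrogen. Among the compounds with values here, the only measured step at this position is the one from compound 2 to compound 3, where removing a para-substituted phenyl from the amide nitrogen in favour of butyl raised the number modestly. The change to compound 4 runs the other way, restoring a para-substituted phenyl, so a modest lowering of the number is expected, a 2.1-fold lower number from compound 3 to compound 4 (0.32 log units; beyond the scatter). Compound 1 also carries 4-chlorophenyl on its amide nitrogen yet sits at the limit, so a limit reading cannot be excluded. The estimate for compound 4 is 45000 nM, with a range of 15000 nM to 140000 nM.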

Compound 4, half-maximal inhibitory concentration: > 100000 nM
Compound 4 was reported as a limit; the forecaster's own chance of this, stated with the estimate: 30%; middle value at least 2.2-fold (0.34 log units) away from the limit.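

Compound 4 joins compound 1 as a limit reading rather than a number: the limit of > 100000 nM in this assay, at which 2 of the 4 values shown sit. In this assay, with benzyl kept on the amide-type nitrogen in a ring, chloro in place of ethoxy on an aromatic carbon gives an at least 2.3-fold higher number from compound 2 to compound 4 (0.37 log units; beyond the scatter), so a para-free reading of the earlier step fails: an aromatic ring on the amide nitrogen does not by itself carry the lower number of compound 2. Against butyl, 4-chlorophenyl gives an at least 1.0-fold higher number from compound 3 to compound 4 (0.02 log units; that floor lies within the scatter), so the direction of this change stays unsettled.

From the compounds shown here alone, the step between compound 1 and compound 4 cannot be read, both values being limits, so benzyl against 4-methylphenyl on the amide-type nitrogen in a ring remains open. Also open, going by these compounds, is whether an amine or a carboxylic acid in place of ethoxy on the aromatic carbon, or a longer chain in place of butyl, would give a lower number.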